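The source may report more compounds than this note shows. Statements on the series, on what has been measured and on what is new or still open speak of the compounds shown alone.

Measured in a functional assay on MCF7 cells (Homo sapiens) for inhibition, read by MTT assay, with a stated time of 48 h; a lower number here means a stronger inhibitor, a higher number a weaker inhibitor:
compound 1 `COc1ccc(/C=C/c2cc(OC)cc(OC)c2/C=C/C(=O)N2CCCCC2)cc1` gives 6050 nM
compound 2 `COc1ccc(/C=C/c2cc(OC)cc(OC)c2/C=C/C(=O)N2CCC(c3ccccc3)CC2)cc1` gives 4230 nM
Not yet measured: compound 3 `CCCCCCNC(=O)/C=C/c1c(/C=C/c2ccc(OC)cc2)cc(OC)cc1OC`

For the measured compounds named here, only two numbers exist so far. Going by the values given here, compound 2 stands at 4230 nM and its one neighbour, compound 1, stands at 6050 nM in the same test, so the two cannot be told apart within the usual scatter. Compound 3 has hexylamino in place of 4-phenylpiperidin-1-yl on a carbonyl carbon. Among the compounds with values here, the only measured step that bears on this swap is phenyl in place of hydrogen on a saturated ring carbon (a 1.4-fold lower number from compound 1 to compound 2 (0.16 log units; within the scatter)), and it lies within the scatter. Within the data shown here, no measured compound carries an open chain or an amide hydrogen here, so the guide is weak and the range stays wide. The expected step is no larger than the scatter (a 1.2-fold higher number from compound 2 to compound 3 (0.07 log units; within the scatter)). Compound 3 is estimated at 5000 nM (expected range 2000 nM to 12000 nM).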

Compound 3, half-maximal inhibitory concentration: 5530 nM
Beside the measured number, compound 3's estimate is 1.1-fold (0.04 log units) below it; measured number inside the range.
By their numbers in this assay, from the lowest: compounds 2, 3 and 1 (each within the scatter of the next).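

In this assay, the swap of 4-phenylpiperidin-1-yl for hexylamino on the carbonyl carbon gives a 1.3-fold higher number from compound 2 to compound 3 (0.12 log units; within the scatter) and the swap of piperidin-1-yl for hexylamino gives a 1.1-fold lower number from compound 1 to compound 3 (0.04 log units; within the scatter) as its result. Both steps lie within the scatter, so among these three compounds an open chain carrying an amide hydrogen cannot be told apart from either ring at this position. No measured evidence is available to explain why the three compounds read alike.

Still open, from the compounds shown here alone, is how a shorter chain such as butyl or a longer chain such as octyl would read in this place, or a chain ending in an amine or a carboxylic acid. A methyl group on the amide nitrogen of the hexyl chain would show whether the amide hydrogen matters on its own.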